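Methyl Added Alongside an Amide Nitrogen in Two Salicylamide Series

A few compounds are considered here, and "the series" means these few. Any claim that something is new, unique, unknown or untested is made for them only; others in the source may bear on it.

Compound 1 `O=C(NCc1ccc(Cl)cc1)c1cc(Cl)ccc1O` and compound 2 `C[C@@H](NC(=O)c1cc(Cl)ccc1O)c1ccc(Cl)cc1` share one core, while compound 3 `O=C(CNC(=O)c1cc(Cl)ccc1O)Nc1ccc([N+](=O)[O-])cc1Cl` carries a second core; the difference between the two cores is not broken down here. In an ADME assay on A549 cells (Homo sapiens) for cytotoxicity, read by resazurin assay, with a stated time of 48 h (a lower number here means that less compound is tolerated, a higher number that more compound is tolerated), compound 1 gives 27100 nM, compound 2 gives 31100 nM, and compound 3 gives 129000 nM. The change methyl in place of hydrogen on a saturated chain carbon bound to an amide-type nitrogen and an aromatic carbon produced a 1.1-fold higher number from compound 1 to compound 2 (0.06 log units; within the scatter). Compound 4 `C[C@H](NC(=O)c1cc(Cl)ccc1O)C(=O)Nc1ccc([N+](=O)[O-])cc1Cl` has not yet been measured; it arises from compound 3 by methyl in place of hydrogen on a saturated chain carbon bound to an amide-type nitrogen and a carbonyl carbon, the same kind of change, though here the saturated chain carbon is bound to a carbonyl carbon rather than an aromatic carbon. On this basis the step is expected to be a 1.0-fold higher number from compound 3 to compound 4 (0.00 log units; within the scatter), resting on compound 3 at 129000 nM and the earlier small step. Compound 4 is therefore estimated at 130000 nM, between 60000 nM and 270000 nM.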

Compound 4, half-maximal cytotoxic concentration: 100000 nM
Beside the measured number, compound 4's estimate is 1.3-fold (0.11 log units) above it; the range from low to high includes it.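

In this assay, methyl in place of hydrogen on a saturated chain carbon bound to an amide-type nitrogen and a carbonyl carbon gives a 1.3-fold lower number from compound 3 to compound 4 (0.11 log units; within the scatter). Set against the earlier step, the change carries from one core to the other with no difference that can be told from scatter: the same change on two cores in this assay, a 1.1-fold higher number (0.06 log units; within the scatter) from compound 1 to compound 2 and a 1.3-fold lower number (0.11 log units; within the scatter) from compound 3 to compound 4, 1.5-fold (0.17 log units) apart, within the scatter of two such steps. Within the data shown here, this rests on a single pair on each core, so it shows only that the methyl step stays small on these two cores in this assay, not that it would on any other core or in any other assay.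

The compounds shown leave open whether an ethyl group, a longer chain or a carboxylic acid in the same place would behave as methyl does. They also leave open how the opposite stereoisomer of compound 2 or compound 4 would read.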